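The compounds below may be only part of what the source reports. "The series", "measured", "known", "first", "only" and "open" are said of these compounds alone.

Compound 1 `CC[C@H](CCn1cncn1)c1ccccc1` is the starting point of this comparison. In an ADME assay on RD cells (Homo sapiens) for cytotoxicity, read by MTT assay, with a stated time of 3 days (on this read-out higher numbers stand for lower toxicity in this test and lower numbers for higher toxicity in this test), compound 1 gives 99.8 ug/mL, the highest of the two numbers at hand. Among the compounds with values here, its only measured neighbour, compound 2 `CC[C@H](CCn1cncn1)c1ccc(C)cc1`, gives 85.2 ug/mL in this assay; the step of a 1.2-fold lower number from compound 1 to compound 2 (0.07 log units; within the scatter) is the one change that has been followed so far. Compound 3 `CCC[C@H](CCn1cncn1)c1ccccc1` is not yet measured. It differs from compound 1 by methyl in place of hydrogen on a saturated chain carbon, three bonds along the chain from an aromatic carbon. Within the data shown here, no measured step matches this chain change; the single step known was within the scatter, so a step of similar size in this assay is expected. Compound 3 is therefore estimated at 88 ug/mL, within 55 ug/mL to 140 ug/mL, a step of a 1.1-fold lower number from compound 1 to compound 3 (0.05 log units; within the scatter).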

Compound 3, half-maximal cytotoxic concentration: 63.1 ug/mL
For compound 3 the middle estimate is 1.4-fold (0.14 log units) above the measured one; the range from low to high includes it.
By their numbers in this assay, from the lowest: compounds 3, 2 and 1 (each within the scatter of the next).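

In this assay, within the data shown here, the step of a 1.6-fold lower number from compound 1 to compound 3 (0.20 log units; within the scatter) gives the first reading at a saturated chain carbon, where the earlier compounds covered only an aromatic carbon. At this place, going from ethyl to propyl keeps the number within the scatter of compound 1. No evidence at hand gives a reason for this result. Going by these compounds, it remains open whether a longer chain, such as butyl, would also stay within the scatter, and whether an amine or a carboxylic acid on this chain carbon would move the number beyond it.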